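Pyridyl imine as successor to the hydroxyphenyl compound

The source may report more compounds than this note shows. Statements on the series, on what has been measured and on what is new or still open speak of the compounds shown alone.

Compound 2 `CC1CCC(/C=N/c2ccc(O)cc2)=C2NC=C(C(=O)O)C(=O)N21` gives the lowest number of the three measured compounds in a functional assay on the whole organism with Rattus norvegicus as the target (a higher number here means that more compound is needed for the effect, a lower number that less compound is needed), with compound 2 at 1.2 umol/kg. Compound 1 `CC1CCC(/C=N/c2ccc(F)cc2)=C2NC=C(C(=O)O)C(=O)N21` gives 10.6 umol/kg in this assay, and compound 3 `CC1CCC(/C=N/c2ccc(CC(=O)O)cc2)=C2NC=C(C(=O)O)C(=O)N21` gives 5.8 umol/kg. Both neighbours lie beyond the scatter from compound 2: an 8.8-fold lower number from compound 1 to compound 2 (0.95 log units; beyond the scatter) and a 4.8-fold higher number from compound 2 to compound 3 (0.68 log units; beyond the scatter). Between compound 1 and compound 3 the step is a 1.8-fold lower number from compound 1 to compound 3 (0.26 log units; within the scatter).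

Compound 4 `CC1CCC(/C=N/c2cccnc2)=C2NC=C(C(=O)O)C(=O)N21` differs from compound 2 in one place: pyridin-3-yl in place of 4-hydroxyphenyl on a double-bonded nitrogen. The two steps that bear on this change are those in which the hydroxy group is present or absent, an 8.8-fold lower number from compound 1 to compound 2 (0.95 log units; beyond the scatter) and a 4.8-fold higher number from compound 2 to compound 3 (0.68 log units; beyond the scatter); both show a clearly higher number whenever the hydroxy group is lacking, and the pyridin-3-yl group likewise brings no hydrogen-bond donor. Going by the values given here, the ring nitrogen keeps one acceptor, for which no measured step exists. Compound 4 is therefore expected to give a higher number than compound 2, the step being estimated as a 4.2-fold higher number from compound 2 to compound 4 (0.62 log units; beyond the scatter). The estimate for compound 4 in this assay is 5 umol/kg, with an expected range from 2 umol/kg to 15 umol/kg.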

Compound 4, dose for 50% inhibition: 2.4 umol/kg
Compound 4: the middle estimate sits 2.1-fold (0.32 log units) above what was measured, within the range that was stated.
By their numbers in this assay, from the lowest: compounds 2 and 4 (each within the scatter of the next); then compounds 3 and 1 (each within the scatter of the next).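

With pyridin-3-yl on the double-bonded nitrogen, a 2.0-fold higher number from compound 2 to compound 4 (0.30 log units; within the scatter), so in this assay this position tolerates replacement of the whole 4-hydroxyphenyl group by a ring that counts no hydrogen-bond donor without a step beyond the scatter. Compound 1 and compound 4 both lack the hydroxy group, yet the change from 4-fluorophenyl to pyridin-3-yl gives a 4.4-fold lower number from compound 1 to compound 4 (0.65 log units; beyond the scatter), so the absence of the hydroxy group does not by itself set the number at this position. Nothing at hand explains why pyridin-3-yl stands apart from 4-fluorophenyl here.

Open, as far as these compounds go, is how pyridin-2-yl or pyridin-4-yl would compare with pyridin-3-yl at this place. Also open, from the compounds shown here alone, is whether an amine on the ring, as in 4-aminophenyl, or a carboxylic acid directly on it, as in 4-carboxyphenyl, would stay within the scatter of compound 2.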